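Benzylidene thiazolidinedione acids on MCF7: fluoro to methoxy

The compounds below may be only part of what the source reports. "The series", "measured", "known", "first", "only" and "open" are said of these compounds alone.

Measured compounds:
compound 1 `Cn1cccc1/C=C1\SC(=O)N(Cc2ccc(C(=O)O)cc2)C1=O` — 70000 nM
compound 2 `O=C(O)c1ccc(CN2C(=O)S/C(=C\c3ccc(F)cc3)C2=O)cc1` — 38000 nM
compound 3 `COc1cccc(/C=C2\SC(=O)N(Cc3ccc(C(=O)O)cc3)C2=O)c1` — 58000 nM

In a functional assay on MCF7 cells (Homo sapiens) for cytotoxicity, read by MTT assay, with a stated time of 24 h (a higher number here means a weaker inhibitor, a lower number a stronger inhibitor), compound 2 has the lowest of the three numbers, yet each gap is within the scatter: a 1.8-fold lower number from compound 1 to compound 2 (0.27 log units; within the scatter) and a 1.5-fold higher number from compound 2 to compound 3 (0.18 log units; within the scatter); likewise a 1.2-fold lower number from compound 1 to compound 3 (0.08 log units; within the scatter). Compound 4 `COc1ccc(/C=C2\SC(=O)N(Cc3ccc(C(=O)O)cc3)C2=O)cc1` differs from compound 2 by methoxy in place of fluoro on an aromatic carbon. For the measured compounds named here, the step from compound 2 to compound 3 is the only one bearing on this change, since it also exchanges fluoro for methoxy on the aryl group, reading 3-methoxyphenyl rather than 4-methoxyphenyl, and it stayed within the scatter, as did both steps from compound 1. No step beyond the scatter is therefore expected from compound 2 to compound 4: a 1.2-fold higher number from compound 2 to compound 4 (0.07 log units; within the scatter). For compound 4 in this assay the estimate is 45000 nM, expected to fall between 20000 nM and 100000 nM.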

Compound 4, half-maximal inhibitory concentration: 48000 nM
Compound 4: the middle estimate sits 1.1-fold (0.03 log units) below what was measured; measured number inside the range.
By their numbers in this assay, from the lowest: compounds 2, 4, 3 and 1 (each within the scatter of the next).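

In this assay, methoxy in place of fluoro on this aromatic carbon, para to a large group, gives a 1.3-fold higher number from compound 2 to compound 4 (0.10 log units; within the scatter), so this direct exchange adds no separation. The two methoxyphenyl groups also stay together, with a 1.2-fold lower number from compound 3 to compound 4 (0.08 log units; within the scatter), and 4-methoxyphenyl in place of 1-methyl-1H-pyrrol-2-yl gives a 1.5-fold lower number from compound 1 to compound 4 (0.16 log units; within the scatter). No supporting data accompany these readings. From the compounds shown here alone, whether an amine or a butoxy group at this position would give a step beyond the scatter remains open.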